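Series notes: from the oxetanol substituent to the methyl

This account rests on a few compounds, and the source may have more. Where it says the series, first, only, none or still open, it means among the compounds named here.

Measured so far in an assay on isolated protein for inhibition of ubiquitin carboxyl-terminal hydrolase 47 (Homo sapiens); a lower number here means a stronger inhibitor, a higher number a weaker inhibitor:
compound 1 `Nc1cc(-c2cc(Cl)cc3c2OC(C(=O)N2CCNCC2)C3)ccn1` — > 80000 nM
compound 2 `O=C([C@H]1Cc2cc(Cl)cc(-c3ccnc4cc(CO)sc34)c2O1)N1CCNCC1` — > 40000 nM
compound 3 `O=C([C@H]1Cc2cc(Cl)cc(-c3ccnc4cc(C5(O)COC5)sc34)c2O1)N1CCNCC1` — > 40000 nM

Among the measured compounds shown here, every value so far is a limit of the assay, not a number. For compound 1 the reading is the limit > 80000 nM. For compound 2 the reading is the limit > 40000 nM. For compound 3 the reading is the limit > 40000 nM. For the measured compounds named here, the single one-place step, a step that the two limits leave unreadable from compound 2 to compound 3, is therefore unreadable; the limit of > 40000 nM in this assay, at which 2 of the 3 values shown sit, and the limit of > 80000 nM in this assay, at which 1 of the 3 values shown sits, mark where all three compounds stand.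

Compound 4 `Cc1cc2nccc(-c3cc(Cl)cc4c3O[C@@H](C(=O)N3CCNCC3)C4)c2s1` differs from compound 3 by methyl in place of 3-hydroxyoxetan-3-yl on an aromatic carbon. Going by the values given here, no measured step bears readably on this change, so no direction beyond the scatter can be set. Compound 4 is therefore expected to stay near the limit, with an estimated value of 60000 nM (range 15000 nM to 250000 nM), an expected step that the limit leaves unreadable from compound 3 to compound 4.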

Compound 4, half-maximal inhibitory concentration: > 80000 nM
Compound 4: a limit, no number (the forecaster's own chance of this, stated with the estimate: 85%); middle value at least 1.3-fold (0.12 log units) from the limit.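

Compound 4 gives > 80000 nM in this assay, which is a limit, so the steps to it from compound 2 and compound 3 cannot be read. The compounds shown leave open whether any substituent at this place gives a measurable value.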